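Furan-3-yl in place of phenyl beside methylsulfanyl

The source may hold more compounds than are shown below. What is called first, only, known or untested is meant among the compounds shown, and "the series" means these compounds.

The four compounds share one core and differ in two groups. Compound 1 `COc1ncnc2c1c(-c1ccoc1)cn2[C@@H]1O[C@H](CO)[C@@H](O)[C@H]1O` carries methoxy and furan-3-yl; in an ADME assay on BJ cells (Homo sapiens), read by MTT assay, with a stated time of 72 h (a lower number here means a stronger inhibitor, a higher number a weaker inhibitor), compound 1 gives 28800 nM. Compound 3 `COc1ncnc2c1c(-c1ccccc1)cn2[C@@H]1O[C@H](CO)[C@@H](O)[C@H]1O` carries methoxy and phenyl. In this assay compound 3 reaches only a limit, > 100000 nM. Compound 2 `CSc1ncnc2c1c(-c1ccccc1)cn2[C@@H]1O[C@H](CO)[C@@H](O)[C@H]1O` carries methylsulfanyl and phenyl. In this assay compound 2 likewise stands at a limit, > 100000 nM. Compound 2 therefore sits at the limit of > 100000 nM in this assay, at which 2 of the 3 values shown sit, and its place among the three cannot be fixed more closely than that. Within the data shown here, compound 4 `CSc1ncnc2c1c(-c1ccoc1)cn2[C@@H]1O[C@H](CO)[C@@H](O)[C@H]1O` is the one not yet measured. furan-3-yl in place of phenyl on an aromatic carbon The only measured step that bears on this change runs the other way, an at least 3.4-fold higher number from compound 1 to compound 3 (0.54 log units; beyond the scatter), while a step that the two limits leave unreadable from compound 2 to compound 3. Read in reverse, furan-3-yl in place of phenyl is expected to lower the number, so compound 4 is estimated at 40000 nM, between 15000 nM and 110000 nM. That would mean an expected step of an at least 2.5-fold lower number from compound 2 to compound 4 (0.39 log units; beyond the scatter).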

Compound 4, half-maximal inhibitory concentration: 98800 nM
Compound 4: the middle estimate sits 2.5-fold (0.39 log units) below what was measured; the range from low to high includes it.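

With furan-3-yl held fixed, the change from methoxy to methylsulfanyl can now be read in this assay, as a 3.4-fold higher number from compound 1 to compound 4 (0.54 log units; beyond the scatter). The change from phenyl to furan-3-yl on this aromatic carbon gives an at least 1.0-fold lower number from compound 2 to compound 4 (0.00 log units; that floor lies within the scatter), so the lower number seen with furan-3-yl and methoxy is not shown to carry over to methylsulfanyl. Whether the phenyl and furan-3-yl exchange differs between the two cores is still undecided: the same change on two cores in this assay, an at least 3.4-fold higher number (0.54 log units; beyond the scatter) from compound 1 to compound 3 and an at least 1.0-fold higher number (0.00 log units; that floor lies within the scatter) from compound 4 to compound 2; the limit leaves it open whether they differ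

As far as these compounds go, compound 2 stands only at a limit of the assay, > 100000 nM, and the true size of its step to compound 4 stays open. The compounds shown also leave open how an amine or an ethylsulfanyl chain in place of methoxy or methylsulfanyl would read in this assay.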